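The compounds below may be only part of what the source reports. "The series", "measured", "known", "first", "only" and "open" are said of these compounds alone.

Compound 1, `Cc1cc(-n2cc(C(=O)Nc3cc(F)cc(F)c3)c(=O)c3ccc(N(C)C)nc32)ccc1OCCCCCCC[N+]1(C)CCCCC1`, was tested in an assay on LX2 cells for inhibition of COL1A1 promoter (Homo sapiens), read by a luciferase reporter, with a stated time of 24 h, tested at 20 uM; a higher number here means a stronger effect of the compound at the concentration tested, a lower number a weaker effect. Within the data shown here, compound 1 gives 33% there, and this is the only numerical result among the compounds measured so far. Compound 2, `CN1CC[N+](C)(CCCCCCCOc2ccc(-n3cc(C(=O)Nc4cc(F)cc(F)c4)c(=O)c4ccc(N(C)C)nc43)c(F)c2)CC1`, is recorded in this assay as "not active" (no number reported), with no figure attached, so no step can be read between compound 2 and compound 1. Compound 3, `CC[N+]1(CCCCCCCOc2ccc(-n3cc(C(=O)Nc4cc(F)cc(F)c4)c(=O)c4ccc(N(C)C)nc43)cc2C)CCCC1`, has not yet been measured in this assay. It differs from compound 1 only in the charged group at the end of the chain: a group of 7 heavy atoms (6 carbon, 1 nitrogen; one five-membered non-aromatic ring with 1 hetero atom) in place of a group of 7 heavy atoms (6 carbon, 1 nitrogen; one six-membered non-aromatic ring with 1 hetero atom), on a saturated chain carbon, seven bonds along the chain from an oxygen on an aromatic ring. The two compounds contain the same atoms, joined differently, and the group that leaves and the group that enters each carry a single positive charge and neither hydrogen-bond donors nor acceptors. Among the measured compounds shown here, with no measured step of a similar kind to lean on, the change is expected to produce a shift of about a number 3 percentage points lower from compound 1 to compound 3 (within the scatter), which lies within the usual scatter of this assay in either direction. Compound 3 is accordingly expected to give 30% in this assay, with a likely range from 15% to 45%.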

Compound 3, a percentage reported as inhibition, at one concentration (the size of the read-out at that concentration, not a potency): 44.7%
Compound 3: the middle estimate sits 14.7 percentage points below what was measured; the range from low to high includes it.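

In this assay, this first measured step shows that the charged group at the end of the chain matters to the read-out: placing the five-membered non-aromatic ring where the six-membered non-aromatic ring stood gives a number 11.7 percentage points higher from compound 1 to compound 3 (beyond the scatter). The two groups match in heavy atoms and in net charge, so a rearrangement of the same atoms, with nothing added or removed, was enough to move the result beyond the usual scatter, though only modestly. Nothing at hand explains why this rearrangement has this effect.

Compound 2 carries no number, so steps involving it cannot be read, and a single comparison at one concentration says nothing about potency or about a trend across ring sizes. From the compounds shown here alone, it remains open whether an open-chain trimethylammonium group at the same position would raise or lower the read-out, and whether a longer chain would preserve the difference seen here.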